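A few compounds are considered here, and "the series" means these few. Any claim that something is new, unique, unknown or untested is made for them only; others in the source may bear on it.

Measured so far:
compound 1 `COc1ccccc1-c1csc(N/N=C/c2ccc(F)c(F)c2)n1`: 40600 nM
compound 2 `Fc1ccc(/C=N/Nc2nc(-c3ccccc3)cs2)cc1F`: > 100000 nM
compound 3 `COc1cc(/C=N/Nc2nc(-c3ccccc3)cs2)cc(Br)c1OC`: 74100 nM

In a functional assay on U-87MG ATCC cells for inhibition, with U-87 MG (Homo sapiens) as the target, read by MTT assay, with a stated time of 48 h (on this read-out higher numbers stand for weaker inhibition and lower numbers for stronger inhibition), compound 1 gives 40600 nM. For compound 2 the read-out is only a limit of the assay, > 100000 nM. Compound 3 gives 74100 nM in this assay. Compound 1 is made from compound 2 by methoxy in place of hydrogen on an aromatic carbon, and that step reads an at least 2.4-fold lower number from compound 2 to compound 1 (0.39 log units; beyond the scatter); it can only be given as a bound because of the limit of > 100000 nM in this assay, at which 1 of the 3 values shown sits. The difference between the cores of compound 2 and compound 3 is not broken down here. Compound 4 `COc1ccccc1-c1csc(N/N=C/c2cc(Br)c(OC)c(OC)c2)n1` is compound 3 with the same change, (methoxy in place of hydrogen on an aromatic carbon). Because compound 2 to compound 1 gave an at least 2.4-fold lower number from compound 2 to compound 1 (0.39 log units; beyond the scatter), a step of similar size is expected from compound 3 to compound 4 in this assay. The expected step is a 2.5-fold lower number from compound 3 to compound 4 (0.39 log units; beyond the scatter). Compound 4 is thus expected to give about 30000 nM, likely between 10000 nM and 90000 nM.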

Compound 4, half-maximal inhibitory concentration: > 100000 nM
Compound 4: a limit, no number (the forecaster's own chance of this, stated with the estimate: 10%); middle value at least 3.3-fold (0.52 log units) away from the limit.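

Compound 4 gives > 100000 nM in this assay, which is a limit of the assay and not a number. Methoxy in place of hydrogen on an aromatic carbon gives an at least 1.3-fold higher number from compound 3 to compound 4 (0.13 log units; that floor lies within the scatter), so the lower number seen on the other core does not carry over to this one: the same change on two cores in this assay, an at least 2.4-fold lower number (0.39 log units; beyond the scatter) from compound 2 to compound 1 and an at least 1.3-fold higher number (0.13 log units; that floor lies within the scatter) from compound 3 to compound 4, at least 3.3-fold (0.52 log units) apart, beyond the scatter of two such steps How large either step truly is cannot be read, and these values do not tell why the two cores differ: the limit of > 100000 nM in this assay, at which 2 of the 4 values shown sit.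

The compounds shown leave open whether another group on that aromatic carbon, such as an amine or a carboxylic acid, would act alike on both cores. They also leave open whether a longer chain in place of methoxy would bring either core's number clear of the limit.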